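A few compounds are considered here, and "the series" means these few. Any claim that something is new, unique, unknown or untested is made for them only; others in the source may bear on it.

Measured so far:
- compound 1, `COCCCn1c(N2CCN(C)CC2)nc2ccccc21`: 860 nM
- compound 2, `CCCCCCCn1c(N2CCN(C)CC2)nc2ccccc21`: 150 nM

Within the data shown here, compound 2 carries the lowest of the two numbers in a functional assay on ileum for inhibition of histamine H1 receptor (Cavia porcellus) (a lower number here means a stronger inhibitor, a higher number a weaker inhibitor), with compound 1 as its only neighbour at a 5.7-fold lower number from compound 1 to compound 2 (0.76 log units; beyond the scatter).

Compound 3, `CN1CCN(c2nc3ccccc3n2CCOCCO)CC1`, is to be measured in this assay. Against compound 2 the change is 2-hydroxyethoxy in place of pentyl on a saturated chain carbon, two bonds along the chain from an aromatic nitrogen. Among the measured compounds shown here, the only measured step that bears on it is a 5.7-fold lower number from compound 1 to compound 2 (0.76 log units; beyond the scatter), where an oxygen-bearing chain was exchanged for a plain alkyl chain and the number fell. Compound 3 runs the other way: the alkyl chain is cut back and two oxygens and a hydrogen-bond donor enter. For the measured compounds named here, compound 3 therefore resembles compound 1 more than compound 2 in the side chain, and the step is expected to go upward, of about the size seen from compound 1 to compound 2, though the chain of compound 3 is still longer than that of compound 1 and carries a hydroxyl that no measured compound has, so the range is wide. The estimate for compound 3 is 1500 nM (range 500 nM to 4500 nM), which means an expected step of a 10-fold higher number from compound 2 to compound 3 (1.00 log units; beyond the scatter).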

Compound 3, half-maximal inhibitory concentration: 42 nM
Beside the measured number, compound 3's estimate is 36-fold (1.55 log units) above it; the whole stated range lies above it.
By their numbers in this assay, from the lowest: compound 3; then compound 2; then compound 1.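

In this assay, the position on a saturated chain carbon, two bonds along the chain from an aromatic nitrogen, accepts oxygen in the side chain: 2-hydroxyethoxy in place of pentyl gives a 3.6-fold lower number from compound 2 to compound 3 (0.55 log units; beyond the scatter) and 2-hydroxyethoxy in place of methoxymethyl gives a 20-fold lower number from compound 1 to compound 3 (1.31 log units; beyond the scatter) within the same series. Read alone, a 5.7-fold lower number from compound 1 to compound 2 (0.76 log units; beyond the scatter) pointed towards a plain alkyl chain, but oxygen in the chain does not by itself raise the number, as the two oxygen-bearing chains of compound 1 and compound 3 now stand at opposite ends of the order, with the pentyl-bearing compound 2 in the middle. No supporting data bear on what lies behind this order.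

The compounds shown do not separate the contribution of the terminal hydroxyl from that of the ether oxygen, and they do not show whether the chain length or the placement of the oxygen matters more. A 2-methoxyethoxy group, a plain pentyl chain ending in hydroxyl, or a chain ending in an amine or a carboxylic acid at this position would each bear on that question.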